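From benzyl to 2-hydroxyphenyl on the amide-type nitrogen

The source may report more compounds than this note shows. Statements on the series, on what has been measured and on what is new or still open speak of the compounds shown alone.

In a functional assay on LNCaP cells (Homo sapiens) for inhibition, read by MTT assay (on this read-out higher numbers stand for weaker inhibition of growth and lower numbers for stronger inhibition of growth), compound 1 `CC1=C(/C=C/C(C)=C/C=C/C(C)=C\C(=O)Nc2ccc(F)cc2)C(C)(C)CCC1n1ccnc1` gives 3890 nM. Compound 2 `CC1=C(/C=C/C(C)=C/C=C/C(C)=C\C(=O)NCc2ccccc2)C(C)(C)CCC1n1ccnc1` gives > 100000 nM, which is a limit of the assay and not a number. Compound 2 therefore has no measured position, only a limit.

Compound 3 `CC1=C(/C=C/C(C)=C/C=C/C(C)=C\C(=O)Nc2ccccc2O)C(C)(C)CCC1n1ccnc1` carries 2-hydroxyphenyl in place of the benzyl of compound 2 on an amide-type nitrogen: 2-hydroxyphenyl in place of benzyl on an amide-type nitrogen.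

Among the measured compounds shown here, one measured step bears on this change: an at least 25-fold higher number from compound 1 to compound 2 (1.41 log units; beyond the scatter), large and beyond the scatter, with benzyl in place of 4-fluorophenyl at the same place. Its size rests on (the limit of > 100000 nM in this assay, at which 1 of the 2 values shown sits), so only its lower bound is known. For the measured compounds named here, compound 3 partly reverses that step, as benzyl leaves and a substituted phenyl enters, but no measured compound carries 2-hydroxyphenyl. A large move in this assay towards a lower number, meaning stronger inhibition of growth, is therefore expected, with a value in the region of compound 1 and a wide margin.

The expected size of the change is an at least 16-fold lower number from compound 2 to compound 3 (1.22 log units; beyond the scatter).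

The estimate for compound 3 is 6000 nM, with an expected range from 1500 nM to 30000 nM.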

Compound 3, concentration for 50% growth inhibition: 3230 nM
Beside the measured number, compound 3's estimate is 1.9-fold (0.27 log units) above it; the measured number falls inside the stated range.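

In this assay, 2-hydroxyphenyl on the amide-type nitrogen brings back measurable inhibition of growth where benzyl showed none up to the assay's limit, with an at least 30-fold lower number from compound 2 to compound 3 (1.49 log units; beyond the scatter). Compound 2's > 100000 nM is a limit of the assay and not a number, so that step has only a lower bound: the limit of > 100000 nM in this assay, at which 1 of the 3 values shown sits.

Against 4-fluorophenyl at the same place the change is a 1.2-fold lower number from compound 1 to compound 3 (0.08 log units; within the scatter), so 2-hydroxyphenyl and 4-fluorophenyl cannot be told apart on this read-out, and the two substituted phenyl groups shown, with different substituents, sit at one level while benzyl stands apart from both.

Open, from the compounds shown here alone, is whether plain phenyl on this nitrogen would hold the same level of growth inhibition, which would show whether the hydroxyl or the fluorine contributes anything at all. Also open, going by these compounds, is whether the loss with benzyl belongs to the extra methylene carbon or to the missing ring substituent, a question that a 2-hydroxybenzyl group or a longer chain such as 2-phenylethyl would address.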